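Swapping a Hydroxyphenyl for a Furan Ring

The source may report more compounds than this note shows. Statements on the series, on what has been measured and on what is new or still open speak of the compounds shown alone.

Compound 1 `CC1=CC[C@H](C(C)(C)NC(=S)N/N=C/c2ccc(O)cc2)CC1` reaches only the limit of > 100000 nM in a functional assay on K562 cells (Homo sapiens) for inhibition, read by sulforhodamine B assay, with a stated time of 48 h (a lower number here means a stronger inhibitor of growth, a higher number a weaker inhibitor of growth), so that result is a limit rather than a number. Compound 2 `CC1=CC[C@H](C(C)(C)NC(=S)N/N=C/c2ccccc2O)CC1` gives 800 nM there, and compound 3 `CC1=CC[C@H](C(C)(C)NC(=S)N/N=C/c2ccccc2[N+](=O)[O-])CC1` gives 300 nM. Among the two numbers shown, compound 2 stands highest, with compound 3 as its nearest neighbour. The large step of an at least 120-fold lower number from compound 1 to compound 2 (2.09 log units; beyond the scatter) shows that moving the hydroxy on the ring matters greatly, while the modest step of a 2.7-fold lower number from compound 2 to compound 3 (0.43 log units; beyond the scatter) shows that exchanging the hydroxy itself changes less. Compound 4 `CC1=CC[C@H](C(C)(C)NC(=S)N/N=C/c2ccco2)CC1` carries furan-2-yl in place of 2-hydroxyphenyl on a carbon with a double bond to nitrogen. Neither measured step removes the six-membered ring, so they bear on this change only loosely, and the step expected in this assay is a 2.5-fold higher number from compound 2 to compound 4 (0.40 log units; beyond the scatter), a small rise. Compound 4 is estimated at 2000 nM, within 500 nM to 8000 nM.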

Compound 4, concentration for 50% growth inhibition: 100 nM
The estimate for compound 4 lay 20-fold (1.30 log units) above the measured number; the measured number lies below the stated range.
By their numbers in this assay, from the lowest: compound 4; then compound 3; then compound 2. At a limit, above all of these: compound 1.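

In this assay, the position on a carbon with a double bond to nitrogen does not need a six-membered aromatic ring or a hydroxy group for a low number, as furan-2-yl in place of 2-hydroxyphenyl gives an 8.0-fold lower number from compound 2 to compound 4 (0.90 log units; beyond the scatter). Furan-2-yl in place of 4-hydroxyphenyl gives an at least 1000-fold lower number from compound 1 to compound 4 (3.00 log units; beyond the scatter). Among the compounds shown here, that step starts from a limit, the one held by compound 1: the limit of > 100000 nM in this assay, at which 1 of the 4 values shown sits.

The compounds shown leave open whether the drop follows the smaller ring or its oxygen, as thiophen-2-yl or pyrrol-2-yl would test. They also leave open how unsubstituted phenyl compares.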